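This account rests on a few compounds, and the source may have more. Where it says the series, first, only, none or still open, it means among the compounds named here.

Compound 1 `CCOCCOc1cccc2ccc(N)nc12` carries an ethoxy group on a chain attached through an oxygen to its core. In an assay on cells with melanin-concentrating hormone receptor 1 (Homo sapiens) as the target, read by radioligand binding (on this read-out lower numbers stand for stronger inhibition and higher numbers for weaker inhibition), compound 1 gives > 2000 nM, which is a limit of the assay rather than a measured number. Compound 2 `Nc1ccc2cccc(OCCC(F)(F)F)c2n1` differs in one place, and in this assay compound 2 gives 722 nM. That single change produced an at least 2.7-fold lower number from compound 1 to compound 2 (0.44 log units; beyond the scatter); since compound 1 sits at the limit (the limit of > 2000 nM in this assay, at which 1 of the 2 values shown sits), only the lower bound of that step is known.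

Compound 3 `CCCOc1cccc2ccc(N)nc12` is the next compound, and it differs from compound 1 by methyl in place of ethoxy on a saturated chain carbon, two bonds along the chain from an oxygen on an aromatic ring. Like the move to compound 2, this removes the ethoxy from compound 1, though it puts in a smaller group. Going by the values given here, the step from compound 1 to compound 2 is the only measured guide, so a step of the same direction and smaller size is expected, an at least 1.3-fold lower number from compound 1 to compound 3 (0.12 log units; that floor lies within the scatter). Compound 3 is therefore estimated at 1500 nM, within 500 nM to 5000 nM.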

Compound 3, half-maximal inhibitory concentration: 1100 nM
Beside the measured number, compound 3's estimate is 1.4-fold (0.13 log units) above it; the range from low to high includes it.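

In this assay, methyl in place of trifluoromethyl at the end of this chain gives a 1.5-fold higher number from compound 2 to compound 3 (0.18 log units; within the scatter) and so sits within the usual scatter of repeat measurements. Compound 2 alone could not show whether trifluoromethyl was needed at this position, and on these values, the plain propyl chain of compound 3 cannot be told apart from it. Methyl in place of ethoxy gives an at least 1.8-fold lower number from compound 1 to compound 3 (0.25 log units; that floor lies within the scatter) and that floor also lies within the scatter, so the full size of this step stays unknown because the value of compound 1 is a limit of the assay: the limit of > 2000 nM in this assay, at which 1 of the 3 values shown sits.

On these data alone, whether an amine, a carboxylic acid or a longer chain at this position would shift the number beyond the scatter stays open. So does whether any chain here can reach much lower numbers.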